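Trimming the carbamoyl group: compound 4 awaits measurement

This account rests on a few compounds, and the source may have more. Where it says the series, first, only, none or still open, it means among the compounds named here.

Of the compounds shown here, three have been measured in an assay on isolated protein for inhibition of Gonadotropin-releasing hormone receptor (Rattus norvegicus); on this read-out lower numbers stand for stronger inhibition and higher numbers for weaker inhibition: compound 1 `CCCn1c(SCc2cc([N+](=O)[O-])ccc2OC)nc2cc(NC(=O)NC(C)(C)C)ccc21` gives 120 nM, compound 2 `CCCCn1c(SCc2cc([N+](=O)[O-])ccc2OC)nc2cc(NC(=O)NC(C)(C)C)ccc21` gives 330 nM, and compound 3 `COc1ccc([N+](=O)[O-])cc1CSc1nc2cc(NC(=O)NC(C)(C)C)ccc2n1C(C)C` gives 62 nM.

Compound 3 has the lowest number of the three. Its step from compound 2 is a 5.3-fold lower number from compound 2 to compound 3 (0.73 log units; beyond the scatter), the difference between their cores being (isopropyl in place of butyl on an aromatic nitrogen). The gap a 1.9-fold lower number from compound 1 to compound 3 (0.29 log units; within the scatter) lies within the scatter, so compound 1 and compound 3 cannot be ordered. Among the measured compounds a methyl is removed once, (hydrogen in place of methyl on a saturated chain carbon, three bonds along the chain from an aromatic nitrogen), and that step was a 2.8-fold lower number from compound 2 to compound 1 (0.44 log units; beyond the scatter).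

Compound 4 `COc1ccc([N+](=O)[O-])cc1CSc1nc2cc(NC(=O)NC(C)C)ccc2n1C(C)C` has not yet been measured. It differs from compound 3 by hydrogen in place of methyl on a saturated chain carbon bound to an amide-type nitrogen and two saturated chain carbons. This is the same kind of change as from compound 2 to compound 1, but not the same: there the place was a saturated chain carbon three bonds along the chain from an aromatic nitrogen, here it is a saturated chain carbon bound to an amide-type nitrogen and two saturated chain carbons, and the cores differ as well. The expected step of a 1.6-fold higher number from compound 3 to compound 4 (0.21 log units; within the scatter) is therefore kept small, resting only loosely on the earlier 2.8-fold lower number from compound 2 to compound 1 (0.44 log units; beyond the scatter). Compound 4 is estimated at 100 nM, expected between 40 nM and 300 nM.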

Compound 4, half-maximal inhibitory concentration: 280 nM
For compound 4 the middle estimate is 2.8-fold (0.45 log units) below the measured one; measured number inside the range.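

In this assay going from (tert-butyl)carbamoyl to isopropylcarbamoyl gave a 4.5-fold higher number from compound 3 to compound 4 (0.65 log units; beyond the scatter) and so took the number up, whereas the earlier removal of a methyl from the chain on the aromatic nitrogen had brought it down. Hydrogen in place of methyl therefore did not carry a single direction or size from one core to the other: the same change on two cores in this assay, a 2.8-fold lower number (0.44 log units; beyond the scatter) from compound 2 to compound 1 and a 4.5-fold higher number (0.65 log units; beyond the scatter) from compound 3 to compound 4, 12-fold (1.09 log units) apart, beyond the scatter of two such steps

This does not show what lies behind the reversal, since the two steps differ both in the place of the methyl and in the rest of the structure, and one pair each cannot separate place from core.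

The compounds shown leave open whether the tert-butyl to isopropyl step would read the same with propyl or butyl on the aromatic nitrogen. They also leave open how a cyclohexyl or phenyl group on the carbamoyl nitrogen would compare with tert-butyl and isopropyl.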